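Hydroxy for Methoxy in a Cytotoxicity Series

The source may report more compounds than this note shows. Statements on the series, on what has been measured and on what is new or still open speak of the compounds shown alone.

Of the compounds shown here, two on a shared core have been tested in a functional assay on DU-145 cells (Homo sapiens) for cytotoxicity, read by sulforhodamine B assay, with a stated time of 48 h, tested at 10 uM; a lower number here means a stronger effect, a higher number a weaker effect of the compound at the concentration tested. Compound 1 `Cc1cc(O)cc(-c2nn(CC#N)cc2-c2ccnc(-c3ccc(Oc4ccccc4)cc3)c2)c1` gives -100% in this assay. Compound 2 `COc1cc(C)cc(-c2nn(CC#N)cc2-c2ccnc(-c3ccc(N(C)C)cc3)c2)c1` gives -48% in this assay, the higher of the two numbers; the nearest value, that of compound 1, lies lower by a gap beyond the usual scatter. Among the compounds with values here, compound 1 and compound 2 differ from each other in more than one place, so their two values stand on their own and no single step between them can be read.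

Compound 3 `Cc1cc(O)cc(-c2nn(CC#N)cc2-c2ccnc(-c3ccc(N(C)C)cc3)c2)c1` is the next compound and has not yet been measured. It differs from compound 2 as follows: hydrogen in place of methyl on an oxygen on an aromatic ring. Read one bond further out, this is methoxy to hydroxy on the 3-methoxy-5-methylphenyl group, giving 3-hydroxy-5-methylphenyl. Within the data shown here, no measured pair of this kind exists in the set, so the size of the step is open. Compound 1, which also carries the hydroxy, gives the lower number of the two, though it differs from compound 2 elsewhere as well. A moderate step toward a lower number is expected, and the step from compound 2 to compound 3 is estimated at a number 17 percentage points lower from compound 2 to compound 3 (beyond the scatter). Compound 3 is therefore expected to give about -65% in this assay, with a range from -100% to -25%.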

Compound 3, a percentage reported as activity, at one concentration (the size of the read-out at that concentration, not a potency): -66%
Compound 3: the middle estimate sits 1 percentage points above what was measured; measured number inside the range.
By their numbers in this assay, from the lowest: compound 1; then compound 3; then compound 2.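

In this assay, the change from methoxy to hydroxy on the 3-methoxy-5-methylphenyl group now has a measured size, with the dimethylamino group held constant: a number 18 percentage points lower from compound 2 to compound 3 (beyond the scatter), a modest step. Compound 3 also opens a second reading at a different place, since dimethylamino in place of phenoxy on an aromatic carbon, with the hydroxy held constant, gives a number 34 percentage points higher from compound 1 to compound 3 (beyond the scatter), a large step and the bigger of the two. Nothing at hand explains either step, and the data give no cause for them.

Going by these compounds, the step between compound 1 and compound 2 still cannot be read, since those two differ in more than one place, and it remains open whether methoxy to hydroxy keeps its size when phenoxy stands in place of dimethylamino. Also open, on these data alone, is how the 3-hydroxy-5-methylphenyl group would compare with an ethoxy or an amine in place of the hydroxy, or how a morpholine or a carboxylic acid would read in place of dimethylamino.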